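Cyclobutyl for sec-butyl on the side chain

The source may hold more compounds than are shown below. What is called first, only, known or untested is meant among the compounds shown, and "the series" means these compounds.

Three compounds sharing one core were run in an in vitro ADME assay on microsomes from liver (Homo sapiens) for metabolic stability, tested at 5 uM; on this read-out higher numbers stand for a longer-lived compound and lower numbers for a shorter-lived compound. Compound 1 `COCN(c1ccc2c(c1)S(=O)(=O)N=C(c1c(O)c(-c3cccs3)nn(CCC(C)C)c1=O)N2)S(C)(=O)=O` gives 0.183 h. Compound 2 `CC(C)=Cc1nn(CCC(C)C)c(=O)c(C2=NS(=O)(=O)c3cc(NS(C)(=O)=O)ccc3N2)c1O` gives 0.55 h. Compound 3 `CCC(C)CCn1nc(-c2cccs2)c(O)c(C2=NS(=O)(=O)c3cc(NS(C)(=O)=O)ccc3N2)c1=O` reports only a limit, > 1 h. That limit is the limit of > 1 h in this assay, at which 1 of the 3 values shown sits. Compound 4 `CS(=O)(=O)Nc1ccc2c(c1)S(=O)(=O)N=C(c1c(O)c(-c3cccs3)nn(CCC3CCC3)c1=O)N2` is the untested partner of compound 3, and the change between them is cyclobutyl in place of sec-butyl on a saturated chain carbon, two bonds along the chain from an aromatic nitrogen. Among the compounds with values here, no measured pair shows this change, and the three measured compounds all carry different side chains, so the numbers offer no step to lean on. The step that the limit leaves unreadable from compound 3 to compound 4 is expected to stay within the usual scatter, in no particular direction. Compound 4 is therefore estimated at 1.1 h, with a range from 0.5 h to 2.5 h.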

Compound 4, half-life: > 1 h
Compound 4: no number, only a limit; the forecaster's own chance of this, stated with the estimate: 55%; the middle value is on the limit's open side.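

No step can be read from compound 3 to compound 4, because each reports only a limit: the limit of > 1 h in this assay, at which 2 of the 4 values shown sit.

The compounds shown leave open whether cyclobutyl in place of sec-butyl changes the result in this assay at all.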